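A few compounds are considered here, and "the series" means these few. Any claim that something is new, unique, unknown or untested is made for them only; others in the source may bear on it.

Working notes on the series, read in a functional assay on MGC-803 cells (Homo sapiens) for inhibition, read by CCK-8 assay, with a stated time of 48 h; on this read-out higher numbers stand for weaker inhibition and lower numbers for stronger inhibition. Compound 1 `COc1ccc(CN(C(=O)CSC(=S)N2CCCc3cc(C)ccc32)c2cc(OC)c(OC)c(OC)c2)cc1` gives 6490 nM, compound 2 `COc1ccc(CN(C(=O)CN2CCN(C(C)=O)CC2)c2cc(OC)c(OC)c(OC)c2)cc1` gives 12800 nM and compound 3 `COc1cc(N(Cc2ccc(Cl)cc2)C(=O)CSC(=S)N2CCN(C(=O)OC(C)(C)C)CC2)cc(OC)c1OC` gives 12900 nM. Compound 3 therefore stands level with compound 2 and within the scatter of compound 1, so the three values do not separate.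

Compound 4 `COc1cc(N(Cc2ccc(C)cc2)C(=O)CSC(=S)N2CCN(C(=O)OC(C)(C)C)CC2)cc(OC)c1OC` departs from compound 3 in one place, methyl in place of chloro on an aromatic carbon, para to a large group, which turns 4-chlorobenzyl into 4-methylbenzyl.

Within the data shown here, no measured pair isolates this change or any other single change. Among the measured compounds shown here, the only guide is that compound 1 at 6490 nM remains within the scatter of compound 3 at 12900 nM despite differing in more than one place. No step beyond the scatter is therefore expected in this assay, and no direction is favoured with any confidence. The expected change is a 1.2-fold lower number from compound 3 to compound 4 (0.07 log units; within the scatter). For compound 4 the estimated value is 11000 nM, with an expected range from 5000 nM to 24000 nM.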

Compound 4, half-maximal inhibitory concentration: 16700 nM
Beside the measured number, compound 4's estimate is 1.5-fold (0.18 log units) below it, and the stated range covers the measured number.
By their numbers in this assay, from the lowest: compounds 1, 2, 3 and 4 (each within the scatter of the next, the first and the last beyond it).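

Among these compounds, this pair supplies the first single-place step: in this assay, the exchange of 4-chlorobenzyl for 4-methylbenzyl gives a 1.3-fold higher number from compound 3 to compound 4 (0.11 log units; within the scatter) on an aromatic carbon para to a large group. Methyl and chloro at this position therefore do not separate on this read-out, which the earlier compounds, differing from one another in more than one place, could not show. No measurement to hand explains this result.

Going by these compounds, whether an amine or a carboxylic acid at this position would give a step beyond the scatter remains open. Also open, on these data alone, is whether methyl and chloro would stay level here with the other side chains seen in compound 1 and compound 2, where only the chloro-to-methyl exchange on the shared core of compound 3 has been read.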